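This account rests on a few compounds, and the source may have more. Where it says the series, first, only, none or still open, it means among the compounds named here.

Measured compounds:
compound 1 `CC1=C(C(=O)Nc2ccc(C)cc2)C(c2cn(-c3ccccc3)nc2-c2ccccc2)NC(=O)N1` — 71700 nM
compound 2 `CC1=C(C(=O)Nc2ccccc2Cl)C(c2cn(-c3ccccc3)nc2-c2ccccc2)NC(=O)N1` — 66600 nM

In a functional assay on MCF7 cells (Homo sapiens) for inhibition, read by sulforhodamine B assay, with a stated time of 24 h (on this read-out lower numbers stand for stronger inhibition of growth and higher numbers for weaker inhibition of growth), compound 1 gives 71700 nM and compound 2 gives 66600 nM. Within the data shown here, compound 2 holds the lower of the two numbers, yet its only neighbour, compound 1, sits within the scatter of it, since the one measured step is a 1.1-fold lower number from compound 1 to compound 2 (0.03 log units; within the scatter). The two values therefore do not separate the compounds.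

Compound 3 `CC1=C(C(=O)Nc2ccc([N+](=O)[O-])cc2)C(c2cn(-c3ccccc3)nc2-c2ccccc2)NC(=O)N1` differs from compound 2 in one place: 4-nitrophenyl in place of 2-chlorophenyl on an amide-type nitrogen. Among the measured compounds shown here, the single measured step that bears on this change is a 1.1-fold lower number from compound 1 to compound 2 (0.03 log units; within the scatter), which exchanged one ring on the same amide-type nitrogen for another and left the number within the scatter. For the measured compounds named here, no measured pair shows an exchange of the ring on that nitrogen moving the read-out beyond the scatter, and nothing measured addresses the 4-nitrophenyl group itself. On that basis the step from compound 2 to compound 3 is expected to stay within the scatter, as a 1.0-fold lower number from compound 2 to compound 3 (0.01 log units; within the scatter). Compound 3 is estimated at 65000 nM, with a range from 30000 nM to 140000 nM.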

Compound 3, concentration for 50% growth inhibition: 35500 nM
Compound 3: the middle estimate sits 1.8-fold (0.26 log units) above what was measured, and the stated range covers the measured number.
By their numbers in this assay, from the lowest: compounds 3, 2 and 1 (each within the scatter of the next, the first and the last beyond it).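

In this assay, among these compounds, the ring on the amide-type nitrogen gives its first step beyond the scatter: nitro in place of methyl on an aromatic carbon is the one change that separates two compounds (a 2.0-fold lower number from compound 1 to compound 3 (0.31 log units; beyond the scatter)), so this position is not entirely silent, although the step is only modest. Among the compounds shown here, the exchange of 2-chlorophenyl for 4-nitrophenyl on the same nitrogen stays inside the scatter (a 1.9-fold lower number from compound 2 to compound 3 (0.27 log units; within the scatter)), so compound 3 separates from compound 1 but not from compound 2, and the series so far gives one small separation rather than a trend. No evidence is available on what lies behind this separation.

Still open, going by these compounds, is whether an amine or a carboxylic acid on the same aromatic carbon would carry the read-out further from the methyl compound, or whether a longer chain in place of the ring on the amide-type nitrogen would change it at all. Also open is what a change in the shared core would do, for instance an ethyl group in place of its methyl, since the compounds shown vary only in the ring on that nitrogen.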